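Working notes: from compound 3 to compound 4

The compounds below may be only part of what the source reports. "The series", "measured", "known", "first", "only" and "open" are said of these compounds alone.

Values in an ADME assay on HEK293 cells (Homo sapiens) for cytotoxicity, with a stated time of 72 h; a lower number here means that less compound is needed, a higher number that more compound is needed for the effect:
compound 1 `C=C[C@@](C)(/C=C/c1ccc(OC)cc1)CCC=C(C)C`: > 36600 nM
compound 2 `C=C[C@@](C)(/C=C/c1ccc(O)cc1)CC/C=C(C)/C=N/N`: > 36600 nM
compound 3 `C=C[C@@](C)(/C=C/c1ccc(O)c(C=O)c1)CCC=C(C)C`: > 36600 nM

Each of these entries is a limit of the assay and not a number. Compound 3 gives only the limit > 36600 nM, so it has no measured position in the series. The other two compounds give no number either (the limit of > 36600 nM in this assay, at which 3 of the 3 values shown sit). Among the measured compounds shown here, no step between measured compounds is available to size the next change.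

Compound 4 `C=C[C@@](C)(/C=C/c1ccc(O)c(/C=C/C(N)=O)c1)CCC=C(C)C` carries 2-carbamoylethenyl in place of formyl on an aromatic carbon, ortho to a hydroxy group (2-carbamoylethenyl in place of formyl on an aromatic carbon). In this assay no step beyond the scatter is expected for this change, and compound 4 is expected to be reported as a limit too, because of the limit of > 36600 nM in this assay, at which 3 of the 3 values shown sit. This expectation rests on three limits, so a number for compound 4 cannot be ruled out. The expected change is a step that the limit leaves unreadable from compound 3 to compound 4 as an estimate. The estimate for compound 4 is 40000 nM, with an expected range from 18000 nM to 80000 nM.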

Compound 4, half-maximal effective concentration: > 36600 nM
Compound 4: only a limit was reported; the forecaster's own chance of this, stated with the estimate: 70%; the middle value lies beyond the limit too.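

Compound 3 and compound 4 are both reported only as limits, so no step can be read between them: the limit of > 36600 nM in this assay, at which 4 of the 4 values shown sit.

The compounds shown leave open what concentration any of them needs for the effect in this assay, and which change to the shared core would yield a number.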